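Chain extension on the dihydroxypyridine-type core: compound 3 to compound 4

The source may hold more compounds than are shown below. What is called first, only, known or untested is meant among the compounds shown, and "the series" means these compounds.

Measured so far in a functional assay on HEK293 cells for agonist activity at G-protein coupled receptor 84 (Homo sapiens), read by calcium flux; a lower number here means that less compound is needed, a higher number that more compound is needed for the effect:
compound 1 `CCCCCc1nc(O)cc(O)n1`: 3670 nM
compound 2 `Oc1cc(C(F)(F)F)nc(SCCCCc2ccccc2)n1`: > 100000 nM, a limit of the assay, not a number
compound 3 `CCCCCCCc1cc(O)cc(O)n1`: 1.26 nM

Compound 3 holds the lowest of the two numbers; compound 1 sits far above it, a gap well beyond the scatter. Compound 2 sits at the limit described in the limit of > 100000 nM in this assay, at which 1 of the 3 values shown sits, so its value gives no number to rank. Within the data shown here, no pair among the measured compounds differs in only one place, so no single step has yet been characterised on this series.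

Compound 4 `CCCCCCCCc1cc(O)cc(O)n1` is the next compound and has not yet been measured. It differs from compound 3 by methyl in place of hydrogen on a saturated chain carbon, seven bonds along the chain from an aromatic carbon. The same kind of change, cut one bond further out, reads methyl to ethyl, ethyl to propyl, propyl to butyl: a lengthening of the saturated chain by one carbon at its far end.

Among the measured compounds shown here, the measured compounds give no step of this kind to lean on. The expectation is that the step from compound 3 to compound 4 in this assay stays small, within or close to the scatter, in either direction. Compound 4 is accordingly estimated at 1.5 nM, with a range from 0.3 nM to 8 nM, the step of a 1.2-fold higher number from compound 3 to compound 4 (0.08 log units; within the scatter) being expected rather than known.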

Compound 4, half-maximal effective concentration: 1.34 nM
For compound 4 the middle estimate is 1.1-fold (0.05 log units) above the measured one; the range from low to high includes it.
By their numbers in this assay, from the lowest: compounds 3 and 4 (each within the scatter of the next); then compound 1. At a limit, above all of these: compound 2.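

Among these compounds, this is the first step that changes a single place: in this assay, methyl in place of hydrogen on a saturated chain carbon, seven bonds along the chain from an aromatic carbon, gives a 1.1-fold higher number from compound 3 to compound 4 (0.03 log units; within the scatter). At this position, then, the far end of the saturated chain accepts one more carbon without a shift that can be told from the scatter, and compound 3 and compound 4 cannot be told apart on this read-out. Nothing among the data shown bears on why the two values match.

Going by these compounds, it remains open whether the same holds for a longer chain, or for a chain ending in a hydroxyl group, an amine or a carboxylic acid instead of methyl. Also open, on these data alone, is how a single change on the shared core would read with the chain held fixed, since this one step speaks only for the chain end.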